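A few compounds are considered here, and "the series" means these few. Any claim that something is new, unique, unknown or untested is made for them only; others in the source may bear on it.

Compound 1, `ClCc1ccc(Cn2cnc3c(Cl)ncnc32)cc1`, and compound 2, `ClCc1cccc(Cn2cnc3ncnc(Cl)c32)c1`, are built from the same atoms joined differently; the difference between the two cores is not broken down here. In a functional assay on KM12 cells (Homo sapiens) for cytotoxicity, read by sulforhodamine B assay, with a stated time of 48 h (on this read-out higher numbers stand for lower toxicity in this test and lower numbers for higher toxicity in this test), compound 1 gives 95500 nM, and in this assay compound 2 gives 67600 nM, the two values lying within the scatter of each other. Among the compounds with values here, compound 3, `ClCc1ccc(Cn2cnc3c(Cl)nc(Cl)nc32)cc1`, differs from compound 1 by chloro in place of hydrogen on an aromatic carbon, and in this assay compound 3 gives 5750 nM; the step of a 17-fold lower number from compound 1 to compound 3 (1.22 log units; beyond the scatter) is beyond the scatter and stands as the one measured step. Compound 4, `ClCc1cccc(Cn2cnc3nc(Cl)nc(Cl)c32)c1`, is not yet measured and differs from compound 2 by chloro in place of hydrogen on an aromatic carbon; the place of the entering chloro is described in the same words for both pairs, so the change is taken as the same one. Within the data shown here, the one measured step of this change is a 17-fold lower number from compound 1 to compound 3 (1.22 log units; beyond the scatter), and it is the basis of the estimate. The step is expected to be a 15-fold lower number from compound 2 to compound 4 (1.18 log units; beyond the scatter) in this assay. Compound 4 is thus estimated at 4500 nM, with a range from 1500 nM to 14000 nM expected.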

Compound 4, concentration lethal to 50% of the cells: 74100 nM
Estimate against measurement, compound 4: 16-fold (1.22 log units) below; measured number outside the range, above it.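

The step reads a 1.1-fold higher number from compound 2 to compound 4 (0.04 log units; within the scatter), so in this assay chloro in place of hydrogen on an aromatic carbon, between two ring nitrogen atoms, shows no shift beyond the scatter on this core. The change therefore cannot be carried as one fixed step between these two cores: the same change on two cores in this assay, a 17-fold lower number (1.22 log units; beyond the scatter) from compound 1 to compound 3 and a 1.1-fold higher number (0.04 log units; within the scatter) from compound 2 to compound 4, 18-fold (1.26 log units) apart, beyond the scatter of two such steps This rests on a single pair for each core, and it shows neither why the two cores part nor how the change would behave on any further core.

As far as these compounds go, the difference between the two cores is not broken down into single changes, so it remains open which part of that difference goes with the split between the steps. Also open, from the compounds shown here alone, is how an amine, a methoxy group or a longer chain would behave in place of the chloro at this place on either core.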